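Acetyl to Propanoyl on the Core of Compound 3

A few compounds are considered here, and "the series" means these few. Any claim that something is new, unique, unknown or untested is made for them only; others in the source may bear on it.

Of the compounds shown here, three have been measured in a functional assay on the whole organism with Mus musculus as the target; on this read-out higher numbers stand for an effect only at larger amounts of compound and lower numbers for an effect already at smaller amounts. Compound 1, `CCCS(=O)(=O)N1CCN(C(=O)CC)CC1`, gives 1 mg/kg in this assay. Compound 2, `CC(=O)N1CCN(S(=O)(=O)c2ccc(F)cc2)CC1`, gives 0.01 mg/kg. Compound 3, `CCCS(=O)(=O)N1CCCN(C(C)=O)C1`, gives 1 mg/kg. Compound 3 thus stands level with compound 1 at the digits given, the two together the highest numbers of the set, while compound 2 lies far lower, a gap that is well beyond the usual scatter.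

Compound 4, `CCCS(=O)(=O)N1CCCN(C(=O)CC)C1`, has not yet been measured in this assay. It differs from compound 3 in one place: methyl in place of hydrogen on a saturated chain carbon bound to a carbonyl carbon. Going by the values given here, no measured pair shows this change on the same core, so the step from compound 3 to compound 4 can only be judged from the neighbours. Compound 1 already carries a propanoyl group and gives 1 mg/kg, the same number as compound 3, so a step from compound 3 to compound 4 of no change at the digits printed from compound 3 to compound 4 (within the scatter) is expected, that is none beyond the scatter. Compound 4 is therefore estimated at 1 mg/kg, with a range from 0.3 mg/kg to 3 mg/kg.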

Compound 4, minimum effective dose: > 10 mg/kg
Compound 4 gave a limit, no number; the forecaster's own chance of this, stated with the estimate: 5%; middle value at least 10-fold (1.00 log units) from the limit.
By their numbers in this assay, from the lowest: compound 2; then compounds 1 and 3 (each within the scatter of the next). At a limit, above all of these: compound 4.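

In this assay, going by these compounds alone, acetyl to propanoyl on the core of compound 3 gives the first single change in the set with a step that can be read: an at least 10-fold higher number from compound 3 to compound 4 (1.00 log units; beyond the scatter). Compound 4 gives > 10 mg/kg, which is a limit of the assay and not a number: the limit of > 10 mg/kg in this assay, at which 1 of the 4 values shown sits A single added methyl at this place is thus enough to move the read-out beyond the scatter on this core, and the propanoyl group of compound 1, which gives 1 mg/kg, could not show how that group fares here.

As far as these compounds go, it remains open whether a longer chain such as butanoyl, or an amine on the saturated chain carbon bound to the carbonyl carbon, would shift the read-out on this core. From the compounds shown here alone, it is also open whether acetyl to propanoyl on the core of compound 2 would bring a step of similar size.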